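The compounds below may be only part of what the source reports. "The series", "measured", "known", "first", "only" and "open" are said of these compounds alone.

Measured so far:
compound 1, `CC(=O)Nc1nccc(-c2ccncc2)n1`: 52%
compound 2, `CC(C)(C)c1ncncc1-c1ccccc1`: 48%
compound 3, `CC(C)(C)c1nc(-c2ccccc2)ncc1-c1ccccc1`: < 5%

In a functional assay on the whole organism for inhibition, with Rattus norvegicus as the target, with stated times of 1 h and 3.5 h, at a dose of 100 mg/kg by the oral route (a lower number here means less inhibition, a higher number more inhibition at the dose given (going by the name of the read-out)), compound 1 gives 52% and compound 2 gives 48%. Compound 3 stands at a limit of this assay, reported as < 5%, which is the limit of < 5% in this assay, at which 1 of the 3 values shown sits. Among the measured compounds shown here, that limit is the outcome of the one measured step that reaches compound 3: a number at least 43 percentage points lower from compound 2 to compound 3 (beyond the scatter).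

Compound 4, `CCOC(=O)Nc1ncc(-c2ccccc2)c(C(C)(C)C)n1`, has not yet been measured. It differs from compound 3 in one place: (ethoxycarbonyl)amino in place of phenyl on an aromatic carbon. The phenyl whose entry had produced the large fall from compound 2 to compound 3 now leaves, so that the step to compound 4 runs back toward the substitution pattern of compound 2, with (ethoxycarbonyl)amino entering between two ring nitrogen atoms instead. For the measured compounds named here, compound 1, which carries an acylated amino group on a related core, gives 52%, although no single-place step links it to compound 4.

On that basis compound 4 is expected to regain a large part of the inhibition lost in compound 3, an estimated a number at least 35 percentage points higher from compound 3 to compound 4 (beyond the scatter). The estimate for compound 4 in this assay is 40%, ranging from 10% to 70%.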

Compound 4, a percentage reported as inhibition, in the whole organism at one dose (the size of the read-out at that dose, not a potency): 24%
Beside the measured number, compound 4's estimate is 16 percentage points above it; the range from low to high includes it.
By their numbers in this assay, from the lowest: compound 4; then compounds 2 and 1 (each within the scatter of the next). At a limit, below all of these: compound 3.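

In this assay, the place between two ring nitrogen atoms has now held hydrogen, phenyl and (ethoxycarbonyl)amino on the shared core, and the read-out differs beyond the scatter for each exchange. Putting (ethoxycarbonyl)amino in place of phenyl gives a number at least 19 percentage points higher from compound 3 to compound 4 (beyond the scatter), yet putting it in place of hydrogen gives a number 24 percentage points lower from compound 2 to compound 4 (beyond the scatter), so the new group recovers only part of what was lost with phenyl, and among these three groups hydrogen at this place gives the most inhibition and phenyl the least. Compound 3 stands at a limit and not at a number, so the first of these steps gives only a minimum size and not an exact one: the limit of < 5% in this assay, at which 1 of the 4 values shown sits.

The compounds shown leave open which part of the (ethoxycarbonyl)amino group carries the recovery, a question that a free amine or a methyl group at this place would help to settle. As far as these compounds go, compound 1 differs from compound 4 in more than one place, so whether its acetylamino group would behave differently on this core also remains open.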